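The compounds below may be only part of what the source reports. "The series", "measured", "known", "first", "only" and "open" are said of these compounds alone.

In a functional assay on PC-3 cells (Homo sapiens) for inhibition, read by MTT assay (on this read-out lower numbers stand for stronger inhibition and higher numbers for weaker inhibition), compound 1 (`O=S(=O)(c1ccc(-c2cnc(C3CC3)o2)cc1)N1CCc2ccccc21`) gives 62 nM and shares the low end of the set with compound 3 (`COc1ccc2c(c1)CCN2S(=O)(=O)c1ccc(-c2cnc(C3CC3)o2)cc1`), which gives 82 nM on the same read-out. Compound 2 (`CC1Cc2ccccc2N1S(=O)(=O)c1ccc(-c2cnc(C3CC3)o2)cc1`) stands far off on the high side at 20500 nM in this set of three.

Compound 4 (`Cc1ccc2c(c1)CCN2S(=O)(=O)c1ccc(-c2cnc(C3CC3)o2)cc1`) has not been measured yet. Its change from compound 1 is methyl in place of hydrogen on an aromatic carbon.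

Among the measured compounds shown here, two measured steps bear on this change. The closer guide is a 1.3-fold higher number from compound 1 to compound 3 (0.12 log units; within the scatter) for methoxy in place of hydrogen, also on an aromatic carbon, and that step stays within the scatter. The other is a 330-fold higher number from compound 1 to compound 2 (2.52 log units; beyond the scatter) and it is large, but there the methyl replaced hydrogen on a saturated ring carbon, a different kind of place. It serves only as a warning that one added methyl can move the number a long way in this small set.

The likeliest outcome in this assay is therefore no step beyond the scatter, with some risk towards a higher number. The expected step is an estimated 1.3-fold higher number from compound 1 to compound 4 (0.11 log units; within the scatter). For compound 4 the estimated value is 80 nM (expected range 30 nM to 250 nM).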

Compound 4, half-maximal inhibitory concentration: 189 nM
The estimate for compound 4 lay 2.4-fold (0.37 log units) below the measured number, and the stated range covers the measured number.
By their numbers in this assay, from the lowest: compounds 1 and 3 (each within the scatter of the next); then compound 4; then compound 2.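

In this assay, this aromatic carbon proves sensitive to the choice of group: placing methyl there in compound 4 gives a 3.0-fold higher number from compound 1 to compound 4 (0.48 log units; beyond the scatter), a modest weakening that the methoxy of compound 3 at the same carbon did not produce. Exchanging methoxy for methyl at this carbon gives a 2.3-fold higher number from compound 3 to compound 4 (0.36 log units; beyond the scatter), so the two groups are not interchangeable here, although this is still a far smaller shift than the added methyl on the saturated ring carbon, which gives a 330-fold higher number from compound 1 to compound 2 (2.52 log units; beyond the scatter). No measurement shown here explains why methyl and methoxy differ at this position.

The compounds shown leave open how a chlorine atom, an amine or a longer chain such as ethyl would behave on this same aromatic carbon, and therefore whether methyl is an isolated case or part of a wider trend. They also leave open whether methyl on the other aromatic carbons of this six-membered ring would give a similar modest step, or a smaller or much larger one.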